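Bromo for Methyl on the Amide Aryl Ring

The compounds below may be only part of what the source reports. "The series", "measured", "known", "first", "only" and "open" are said of these compounds alone.

Compound 3 `Cc1cc(C(F)(F)F)ccc1C(=O)NC1(c2ccccc2)CCCN(C)C1` gives 320 nM in an assay on cells for inhibition of sodium- and chloride-dependent glycine transporter 1 (Homo sapiens) (on this read-out lower numbers stand for an effect already at smaller amounts and higher numbers for an effect only at larger amounts of compound), and stands lowest of the two numbers shown, while compound 1 `COc1cc(C(F)(F)F)ccc1C(=O)NC1(c2ccccc2)CCCN(C)C1` gives 4800 nM. Compound 2 `CN1CCCC(NC(=O)c2ccc(C(F)(F)F)cc2C#N)(c2ccccc2)C1` reaches only the assay limit of > 10000 nM, a boundary rather than a number. Replacing methoxy with methyl gave a 15-fold lower number from compound 1 to compound 3 (1.18 log units; beyond the scatter), and replacing cyano with methyl gave an at least 31-fold lower number from compound 2 to compound 3 (1.49 log units; beyond the scatter). Compound 4 `CN1CCCC(NC(=O)c2ccc(C(F)(F)F)cc2Br)(c2ccccc2)C1` differs from compound 3 by bromo in place of methyl on an aromatic carbon. Going by the values given here, no measured step swaps methyl for bromo, so both earlier steps bear only indirectly: they show that this position is sensitive, with methyl the best group seen so far. For compound 4 the expected step is a 1.6-fold higher number from compound 3 to compound 4 (0.19 log units; within the scatter), a small move toward a higher number. Compound 4 is estimated at 500 nM, between 150 nM and 2500 nM.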

Compound 4, half-maximal effective concentration: 300 nM
Compound 4: middle estimate off by 1.7-fold (0.22 log units), on the high side; the range from low to high includes it.
By their numbers in this assay, from the lowest: compounds 4 and 3 (each within the scatter of the next); then compound 1. At a limit, above all of these: compound 2.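

Bromo is the first group at this position to match methyl in this assay, so methyl is not the only group that works here (a 1.1-fold lower number from compound 3 to compound 4 (0.03 log units; within the scatter)). Bromo also keeps the large advantage over methoxy (a 16-fold lower number from compound 1 to compound 4 (1.20 log units; beyond the scatter)) and over cyano (an at least 33-fold lower number from compound 2 to compound 4 (1.52 log units; beyond the scatter)). Compound 2 stands at a limit of the assay, not at a number: (the limit of > 10000 nM in this assay, at which 1 of the 4 values shown sits).

Going by these compounds, whether chloro, ethyl or an amine at this position would keep this level stays open. So does whether bromo and methyl would also match on the other parts of the shared core.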